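A few compounds are considered here, and "the series" means these few. Any claim that something is new, unique, unknown or untested is made for them only; others in the source may bear on it.

Compound 3 `C=CCn1c(=O)/c(=C\c2ccccc2C(F)(F)F)[nH]c(=O)/c1=C\c1ccccc1OC` is the reference point here. In a functional assay on K562 cells (Homo sapiens) for cytotoxicity, read by CCK-8 assay, with a stated time of 72 h (a lower number here means a stronger inhibitor, a higher number a weaker inhibitor), compound 3 gives 2700 nM, the lowest of the two numbers measured in this series. For the measured compounds named here, its nearest neighbour is compound 1 `C=CCn1c(=O)/c(=C\c2cccc(C)c2)[nH]c(=O)/c1=C\c1ccccc1OC`, which in this assay gives 8800 nM; the single measured step, a 3.3-fold lower number from compound 1 to compound 3 (0.51 log units; beyond the scatter), lies beyond the scatter and is of modest size. Compound 2 `C=CCn1c(=O)/c(=C\c2ccc(C)cc2)[nH]c(=O)/c1=C\c1ccccc1OC` was recorded as "not active" (no number reported) in this assay, so it contributes no number.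

Compound 4 `C=CCn1c(=O)/c(=C\c2cccc(Cl)c2Cl)[nH]c(=O)/c1=C\c1ccccc1OC` differs from compound 3 in one place: 2,3-dichlorophenyl in place of 2-(trifluoromethyl)phenyl on a double-bonded chain carbon bound to an aromatic carbon. Going by the values given here, the only step that bears on this exchange is a 3.3-fold lower number from compound 1 to compound 3 (0.51 log units; beyond the scatter), which showed that a 3-methylphenyl group at this position gave a higher number than 2-(trifluoromethyl)phenyl, while compound 2 with 4-methylphenyl gave no measurable activity at all. Among the compounds with values here, compound 4 keeps a substituent at position 2 of the ring and adds one at position 3; no measured pair tests chlorine here, so the expected step is uncertain and is estimated to be no larger than the scatter, perhaps a slight drift upward. Compound 4 is therefore expected to give about 3500 nM in this assay, within a range of 1200 nM to 10000 nM. That estimate corresponds to a step of a 1.3-fold higher number from compound 3 to compound 4 (0.11 log units; within the scatter) from compound 3 to compound 4.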

Compound 4, half-maximal inhibitory concentration: 900 nM
Compound 4: the middle estimate sits 3.9-fold (0.59 log units) above what was measured; measured number below the stated range.
By their numbers in this assay, from the lowest: compound 4; then compound 3; then compound 1.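

In this assay, 2,3-dichlorophenyl on a double-bonded chain carbon bound to an aromatic carbon goes beyond what 2-(trifluoromethyl)phenyl achieved, with a 3.0-fold lower number from compound 3 to compound 4 (0.48 log units; beyond the scatter), and compound 4 now holds the lowest number among the compounds that give one. Measured against 3-methylphenyl the change is larger, with a 9.8-fold lower number from compound 1 to compound 4 (0.99 log units; beyond the scatter), so the aryl group at this place moves the number over a wider span than the earlier pair showed, and a group carrying two chlorine atoms is shown to be accepted there, while compound 2 stays outside this order without a number. Nothing available here explains why the dichlorinated ring gives the lower number.

The compounds shown leave open whether both chlorine atoms are needed for this result or one alone would give it, and whether a ring carrying an amine or a carboxylic acid at this place would go lower still. They also leave open whether the same exchange would give a step of similar size with a longer chain elsewhere on the shared core.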